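The source may report more compounds than this note shows. Statements on the series, on what has been measured and on what is new or still open speak of the compounds shown alone.

Three compounds that share one core and differ only in the group on a saturated chain carbon bound to two aromatic carbons have been tested in a functional assay on HeLa cells (Homo sapiens) for inhibition, read by MTT assay, with a stated time of 48 h; on this read-out higher numbers stand for weaker inhibition and lower numbers for stronger inhibition. There, compound 1 `COc1ccc(C(c2c[nH]c3ccc(Br)cc23)c2c[nH]c3ccc(Br)cc23)c(OC)c1` gives 63200 nM, compound 2 `COc1ccc(OC)c(C(c2c[nH]c3ccc(Br)cc23)c2c[nH]c3ccc(Br)cc23)c1` gives 5100 nM and compound 3 `Brc1ccc2[nH]cc(C(c3c[nH]c4ccc(Br)cc34)C3CCCCC3)c2c1` gives 3200 nM. Compound 3 thus stands level with compound 2, the gap being a 1.6-fold lower number from compound 2 to compound 3 (0.20 log units; within the scatter). Both lie far from compound 1, with large steps of a 20-fold lower number from compound 1 to compound 3 (1.30 log units; beyond the scatter) and a 12-fold lower number from compound 1 to compound 2 (1.09 log units; beyond the scatter).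

The next case is compound 4 `Brc1ccc(C(c2c[nH]c3ccc(Br)cc23)c2c[nH]c3ccc(Br)cc23)cc1`, with 4-bromophenyl in place of cyclohexyl on a saturated chain carbon bound to two aromatic carbons. For the measured compounds named here, no measured step makes this exact change. The nearest guides are the two dimethoxyphenyl compounds, which also carry an aromatic ring at that carbon, and they disagree. Compound 2 shows that such a ring can match cyclohexyl, at a 1.6-fold lower number from compound 2 to compound 3 (0.20 log units; within the scatter), while compound 1 shows that it can cost much more, at a 20-fold lower number from compound 1 to compound 3 (1.30 log units; beyond the scatter). The expected result in this assay is therefore a modest move towards a higher number, a 2.2-fold higher number from compound 3 to compound 4 (0.34 log units; beyond the scatter), with a long upper tail. For compound 4 the estimated value is 7000 nM, within an expected range of 2500 nM to 28000 nM.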

Compound 4, half-maximal inhibitory concentration: 1500 nM
Compound 4: middle estimate off by 4.7-fold (0.67 log units), on the high side, and the stated range ends above it.
By their numbers in this assay, from the lowest: compound 4; then compounds 3 and 2 (each within the scatter of the next); then compound 1.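

In this assay, for the compounds shown here, the replacement of cyclohexyl by 4-bromophenyl gives a 2.1-fold lower number from compound 3 to compound 4 (0.33 log units; beyond the scatter) and shows for the first time that an aromatic ring on this saturated chain carbon can go beyond cyclohexyl, whereas the earlier aromatic examples at best stood level with it. The same ring gives a 3.4-fold lower number from compound 2 to compound 4 (0.53 log units; beyond the scatter) and a 42-fold lower number from compound 1 to compound 4 (1.62 log units; beyond the scatter), so compound 4 has the lowest number of the four, with all its steps beyond the scatter, and the largest step in the set now separates two compounds that both carry a substituted phenyl ring at this carbon. The presence of an aromatic ring therefore does not by itself set the result here, since what that ring carries goes with a wide range of numbers across compounds 1, 2 and 4.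

No evidence at hand accounts for this order. Still open, from the compounds shown here alone, is how plain phenyl, a ring with a single methoxy group, or a quite different group such as an amine, a carboxylic acid or a longer chain would compare on this carbon.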